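Cytotoxicity of Aminopurine Analogues Bearing Varied Alkylamino Groups

This account rests on a few compounds, and the source may have more. Where it says the series, first, only, none or still open, it means among the compounds named here.

Compound 1: `CNc1nc(N)nc2c1ncn2/C=C1/CC1(CO)CO` — 67000 nM
Compound 2: `Nc1nc(NC2CCCC2)c2ncn(/C=C3/CC3(CO)CO)c2n1` — 71700 nM

Within the data shown here, in an ADME assay on BCBL1 cells (Homo sapiens) for cytotoxicity, with a stated time of 7 days (on this read-out lower numbers stand for higher toxicity in this test and higher numbers for lower toxicity in this test), compound 2 gives the higher of the two numbers measured so far, and its only neighbour is compound 1. Among the measured compounds shown here, the one step known between them, a 1.1-fold higher number from compound 1 to compound 2 (0.03 log units; within the scatter), shows that replacing methyl with cyclopentyl on a nitrogen on an aromatic ring left the read-out essentially unchanged.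

Compound 3, `CCCCNc1nc(N)nc2c1ncn2/C=C1/CC1(CO)CO`, has not yet been measured. It differs from compound 2 by butyl in place of cyclopentyl on a nitrogen on an aromatic ring. This step bears on the same position as the step from compound 1 to compound 2, and that step was within the scatter. An alkyl chain in place of a carbocycle of similar size is therefore expected to produce no step beyond the scatter, so a 1.0-fold lower number from compound 2 to compound 3 (0.01 log units; within the scatter) is the expected change. Compound 3 is accordingly estimated to give 70000 nM, within the range 35000 nM to 140000 nM.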

Compound 3, half-maximal cytotoxic concentration: > 20000 nM
Compound 3 ended at the assay's limit (the forecaster's own chance of this, stated with the estimate: 20%); the middle value does not contradict the limit.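

In this assay compound 3 gives > 20000 nM, which is a limit of the assay and not a number. The steps from compound 1 and from compound 2 to compound 3 therefore cannot be read. The compounds shown leave open whether butylamino differs from cyclopentylamino in this read-out.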